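A few compounds are considered here, and "the series" means these few. Any claim that something is new, unique, unknown or untested is made for them only; others in the source may bear on it.

Of the compounds shown here, three with a shared core have been measured in an assay on isolated protein for binding affinity to Equilibrative nucleoside transporter 1 (Homo sapiens); on this read-out higher numbers stand for weaker inhibition and lower numbers for stronger inhibition. Compound 1 `OC[C@H]1O[C@@H](n2cnc3c(OCc4ccccc4)ncnc32)[C@H](O)[C@@H]1O` gives 2090 nM; compound 2 `OC[C@H]1O[C@@H](n2cnc3c(Sc4ccccc4)ncnc32)[C@H](O)[C@@H]1O` gives 91200 nM; compound 3 `OC[C@H]1O[C@@H](n2cnc3c(CSc4ccccc4F)ncnc32)[C@H](O)[C@@H]1O` gives 355 nM. Among these, compound 3 stands lowest, with compound 1 nearest and compound 2 furthest. Going by the values given here, the steps so far all concern the group on the aromatic carbon of the core: a 44-fold higher number from compound 1 to compound 2 (1.64 log units; beyond the scatter), a 5.9-fold lower number from compound 1 to compound 3 (0.77 log units; beyond the scatter) and a 260-fold lower number from compound 2 to compound 3 (2.41 log units; beyond the scatter).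

Compound 4 `O=[N+]([O-])c1cccc(SCc2ncnc3c2ncn3[C@@H]2O[C@H](CO)[C@@H](O)[C@H]2O)c1` differs from compound 3 in another place: 3-nitrophenyl in place of 2-fluorophenyl on a sulfur. Among the compounds with values here, none of the measured steps touches the ring on that sulfur, so no step bears directly on this change; the only guide is that compound 3, the sole compound carrying a sulfur attached to a saturated chain carbon, stands lowest on this assay. On that basis compound 3 to compound 4 is expected to give a small step, probably within the scatter, and compound 4 is estimated at 500 nM, with a range of 120 nM to 2000 nM, corresponding to the expected step of a 1.4-fold higher number from compound 3 to compound 4 (0.15 log units; within the scatter).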

Compound 4, half-maximal inhibitory concentration: 4.79 nM
Compound 4: the middle estimate sits 100-fold (2.02 log units) above what was measured; the whole stated range lies above it.
By their numbers in this assay, from the lowest: compound 4; then compound 3; then compound 1; then compound 2.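

The earlier steps shown here replaced the whole group on the aromatic carbon of the core. This change keeps the sulfur on its saturated chain carbon and alters only the ring on that sulfur, yet in this assay it gives a step (a 74-fold lower number from compound 3 to compound 4 (1.87 log units; beyond the scatter)) that is larger than the one that introduced the ((2-fluorophenyl)sulfanyl)methyl group in place of benzyloxy (a 5.9-fold lower number from compound 1 to compound 3 (0.77 log units; beyond the scatter)). The group on the sulfur is therefore a strong determinant of the read-out in this series, and the data offer no measurement that accounts for the size of this step.

The change removes the fluorine and adds a nitro group together, so the compounds shown do not separate the two contributions. Also open, as far as these compounds go, is whether a plain phenyl, an amine or a nitrile on this ring would keep the number as low.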